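The source may report more compounds than this note shows. Statements on the series, on what has been measured and on what is new or still open speak of the compounds shown alone.

Measured so far:
- compound 1 `CN1C[C@@H](COc2ccc(C(=O)n3ccc4c(CC(=O)O)cccc43)cc2)Oc2ccccc21` — "not determined" (no result reported) in a functional assay on CHO cells for antagonist activity at prostaglandin D2 receptor (Mus musculus), read by cAMP accumulation and immunoassay, with a stated time of 10 min; on this read-out higher numbers stand for weaker inhibition and lower numbers for stronger inhibition
- compound 2 `Cc1cc(OC[C@@H]2CN(C)c3ccccc3O2)cc(C)c1C(=O)Nc1cccc(CC(=O)O)c1` — 3.5 nM

Of the two compounds made, compound 1 `CN1C[C@@H](COc2ccc(C(=O)n3ccc4c(CC(=O)O)cccc43)cc2)Oc2ccccc21` has "not determined" (no result reported) as its entry in this assay, so no number exists for it. Within the data shown here, compound 2 `Cc1cc(OC[C@@H]2CN(C)c3ccccc3O2)cc(C)c1C(=O)Nc1cccc(CC(=O)O)c1` gives 3.5 nM in this assay, and since that is the only number in hand, compound 2 stands alone and cannot be ranked against any other compound. The next compound, compound 3 `Cc1ccc(CC(=O)O)cc1NC(=O)c1c(C)cc(OC[C@@H]2CN(C)c3ccccc3O2)cc1C`, differs from compound 2 in a single place: methyl in place of hydrogen on an aromatic carbon. Among the measured compounds shown here, no pair of measured compounds shows what such a change does in this assay, so any expectation rests on compound 2 alone. A single methyl is a small addition, and the expected step is modest, within or just beyond the usual scatter, with somewhat more chance of a loss than a gain. The step expected is a 1.4-fold higher number from compound 2 to compound 3 (0.15 log units; within the scatter). For compound 3 the expected value is 5 nM, with a range from 1.5 nM to 20 nM.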

Compound 3, half-maximal inhibitory concentration: 4.8 nM
Beside the measured number, compound 3's estimate is 1.0-fold (0.02 log units) above it, within the range that was stated.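

In this assay the swap of hydrogen for methyl on this aromatic carbon, ortho to a large group and para to the carboxymethyl group, gives a 1.4-fold higher number from compound 2 to compound 3 (0.14 log units; within the scatter) and so stays inside the normal spread of repeat measurements. Among these compounds, this is the first reading of any change at this position, and it shows that one added carbon here leaves compound 2 and compound 3 indistinguishable on this read-out. No measured property is at hand to explain this result.

Going by these compounds, whether the position would accept an ethyl, a methoxy or an amine as it accepts methyl remains open. Also open, on these data alone, is whether a methyl on another carbon of the same ring would read the same way.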